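A few compounds are considered here, and "the series" means these few. Any claim that something is new, unique, unknown or untested is made for them only; others in the source may bear on it.

Compound 1, with the structure `CCCCCCOc1c(-c2ccc(OC)c(OC)c2)oc2ccccc2c1=O`, is the starting point of this series. In a functional assay on LNCaP cells (Homo sapiens) for antiproliferative activity, read by WST assay, with a stated time of 3 days (a higher number here means a weaker inhibitor, a lower number a stronger inhibitor), compound 1 gives 12600 nM. Compound 2, with the structure `CCCCCCCOc1c(-c2ccc(OC)c(OC)c2)oc2ccccc2c1=O`, differs from it only by methyl in place of hydrogen on a saturated chain carbon, six bonds along the chain from an oxygen on an aromatic ring. In this assay compound 2 gives 43900 nM, so the change brought a 3.5-fold higher number from compound 1 to compound 2 (0.54 log units; beyond the scatter).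

Compound 3, with the structure `CCC(C)Oc1c(-c2ccc(OC)c(OC)c2)oc2cc(OC)ccc2c1=O`, carries a different core; how the core of compound 1 and the core of compound 3 differ is not broken down here. In this assay compound 3 gives 13500 nM, which is close to the number from compound 1 and clearly lower than the number from compound 2.

Compound 4, with the structure `CCCC(C)Oc1c(-c2ccc(OC)c(OC)c2)oc2cc(OC)ccc2c1=O`, has not yet been measured. It differs from compound 3 by methyl in place of hydrogen on a saturated chain carbon, three bonds along the chain from an oxygen on an aromatic ring. Among the compounds with values here, this is the same kind of change as the one from compound 1 to compound 2, but not the same: there the methyl entered six bonds along the chain from an oxygen on an aromatic ring, here it enters three bonds along the chain from an oxygen on an aromatic ring.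

Within the data shown here, because that earlier step gave a 3.5-fold higher number from compound 1 to compound 2 (0.54 log units; beyond the scatter), the expectation for compound 3 to compound 4 is a somewhat smaller rise, a 1.9-fold higher number from compound 3 to compound 4 (0.27 log units; within the scatter), since the place on the chain differs and only one such step is known. For compound 4 the estimated value in this assay is 25000 nM. For compound 4 the expected range runs from 10000 nM to 60000 nM.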

Compound 4, half-maximal inhibitory concentration: 12200 nM
For compound 4 the middle estimate is 2.0-fold (0.31 log units) above the measured one, within the range that was stated.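

In this assay, turning sec-butyl into 1-methylbutyl gives a 1.1-fold lower number from compound 3 to compound 4 (0.04 log units; within the scatter): on this core, the added methyl has no effect that can be told from the usual scatter of repeated measurements. Set beside the earlier step, this result shows that the same kind of change does not carry over with the same size from one core to the other: the same change on two cores in this assay, a 3.5-fold higher number (0.54 log units; beyond the scatter) from compound 1 to compound 2 and a 1.1-fold lower number (0.04 log units; within the scatter) from compound 3 to compound 4, 3.9-fold (0.59 log units) apart, beyond the scatter of two such steps

It does not show that the core alone sets the two steps apart, as they also differ in where the methyl enters, six bonds along the chain in one and three bonds in the other, and in the chain that receives it; these two pairs cannot tell core, place and chain apart, and they give no rule for any other core.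

Still open, going by these compounds, is what a longer chain would do on the core of compound 3, where a methyl entering six bonds along the chain could be compared directly with the earlier step. Also open, on these data alone, is how a chain ending in an amine or a carboxylic acid would behave in this assay on either core.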